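The source may report more compounds than this note shows. Statements on the series, on what has been measured and on what is new or still open speak of the compounds shown alone.

Compound 1 `C[C@H](O)[C@@H](CCC1CCCCC1)n1cnc2c(N)ncnc21` gives 1.9 nM in an assay on isolated protein for inhibition of adenosine deaminase (Bos taurus), with a stated time of 5 min; on this read-out higher numbers stand for weaker inhibition and lower numbers for stronger inhibition.
Compound 2 `COC(=O)c1cccc(CC[C@H]([C@H](C)O)n2cnc3c(N)ncnc32)c1` gives 2.2 nM in this assay.
Compound 3 `C[C@H](O)[C@@H](CCc1cccc(C(=O)O)c1)n1cnc2c(N)ncnc21` gives 53 nM in this assay.

Compound 3 stands highest of the three numbers in this assay: compound 2 lies a 24-fold higher number from compound 2 to compound 3 (1.38 log units; beyond the scatter) away, and compound 1 is further still. Compound 4 `C[C@H](O)[C@@H](CCc1cccc(C(=O)N(C)C)c1)n1cnc2c(N)ncnc21` is the next step in the series: dimethylamino in place of hydroxy on a carbonyl carbon, that is, carboxy to dimethylcarbamoyl.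

For the measured compounds named here, the one measured step that bears on this change is the one from compound 2 to compound 3, where hydrogen in place of methyl on an oxygen next to a carbonyl group gave a 24-fold higher number from compound 2 to compound 3 (1.38 log units; beyond the scatter). Compound 4 alters the same carboxy group of compound 3, so a step of similar size in the opposite direction is expected in this assay, though whether dimethylamino reproduces the methyl ester fully is not known from these compounds. Compound 4 is therefore expected at a 13-fold lower number from compound 3 to compound 4 (1.12 log units; beyond the scatter), giving an estimated 4 nM with a range of 1.5 nM to 12 nM.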

Compound 4, inhibition constant: 1.8 nM
Compound 4: the middle estimate sits 2.2-fold (0.35 log units) above what was measured, within the range that was stated.
By their numbers in this assay, from the lowest: compounds 4, 1 and 2 (each within the scatter of the next); then compound 3.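

In this assay, the weak result for compound 3 does not extend to every change on this carbonyl carbon: dimethylamino in place of hydroxy gives a 29-fold lower number from compound 3 to compound 4 (1.47 log units; beyond the scatter). Dimethylamino in place of methoxy gives a 1.2-fold lower number from compound 2 to compound 4 (0.09 log units; within the scatter), so dimethylcarbamoyl and the methyl ester are not told apart here, and among compounds 2, 3 and 4 only the carboxy group of compound 3 stands apart. No measurement in hand accounts for this difference.

Going by these compounds, whether a primary carboxamide or a monomethyl amide follows compound 4 or compound 3 remains open, and so does the effect of a larger amine on this carbonyl carbon, such as morpholine. On these data alone, it is also open whether the carbonyl is needed at all, which a nitrile or a hydroxymethyl group in its place would test.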